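Methoxy for fluoro: cytotoxicity outlook for compound 3

This account rests on a few compounds, and the source may have more. Where it says the series, first, only, none or still open, it means among the compounds named here.

Among the compounds with values here, compound 1 `Fc1ccc(-c2nc3cc(C(F)(F)F)ccc3[nH]2)cc1` is the only member of the series with a number in an ADME assay on Vero cells (Chlorocebus sabaeus) for cytotoxicity; on this read-out lower numbers stand for higher toxicity in this test and higher numbers for lower toxicity in this test; compound 1 gives 60000 nM there. Compound 2 `Cn1c(-c2ccc([N+](=O)[O-])cc2)nc2cc(C(F)(F)F)ccc21` reports only a limit of the assay in this assay, > 100000 nM, and this is the limit of > 100000 nM in this assay, at which 1 of the 2 values shown sits. Compound 3 `COc1ccc(-c2nc3cc(C(F)(F)F)ccc3[nH]2)cc1` differs from compound 1 by methoxy in place of fluoro on an aromatic carbon. Within the data shown here, no measured pair differing in one place is at hand, so the step rests on the change alone. The expected step is no change at the digits printed from compound 1 to compound 3 (within the scatter), no more than the usual scatter and in no clear direction. Compound 3 is estimated at 60000 nM, between 30000 nM and 120000 nM.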

Compound 3, half-maximal cytotoxic concentration: 15000 nM
Compound 3: the middle estimate sits 4.0-fold (0.60 log units) above what was measured; the whole stated range lies above it.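

On an aromatic carbon para to a large group, the read-out in this assay responds to the substituent: methoxy in place of fluoro gives a 4.0-fold lower number from compound 1 to compound 3 (0.60 log units; beyond the scatter). Within the data shown here, this is the first readable step, and it points toward higher toxicity in this test. Compound 2 differs from compound 1 in more than one place and adds no step, standing only at a limit of the assay: the limit of > 100000 nM in this assay, at which 1 of the 3 values shown sits.

On these data alone, whether the step comes from gaining methoxy or losing fluoro stays open. Also open, as far as these compounds go, is how an amine or a carboxylic acid on this carbon would read in this assay.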